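The source may report more compounds than this note shows. Statements on the series, on what has been measured and on what is new or still open speak of the compounds shown alone.

Measured compounds:
compound 1 `ClCc1ccccc1Cn1cnc2ncnc(Cl)c21` gives 11200 nM
compound 2 `Nc1nc(Cl)c2ncn(Cc3cccc(CCl)c3)c2n1` gives 13200 nM

In a functional assay on KM12 cells (Homo sapiens) for cytotoxicity, read by sulforhodamine B assay, with a stated time of 48 h (a lower number here means a stronger inhibitor of growth, a higher number a weaker inhibitor of growth), compound 1 gives 11200 nM, and in this assay compound 2 gives 13200 nM. Compound 1 has the lower of the two numbers, but compound 2 sits within the scatter of it, so the two values cannot be told apart and neither compound can be called more or less active than the other. Among the compounds with values here, no step between measured compounds is available for comparison.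

Compound 3 `ClCc1ccccc1Cn1cnc2nc(Cl)nc(Cl)c21` is the unmeasured compound. It differs from compound 1 by chloro in place of hydrogen on an aromatic carbon. Within the data shown here, nothing among the measured compounds shows how such a change affects this assay, so the expected step is uncertain. In the absence of a comparable pair, compound 3 is expected to land close to compound 1, with the estimated step of a 1.2-fold lower number from compound 1 to compound 3 (0.09 log units; within the scatter) not clearly beyond the scatter in either direction. The estimated value for compound 3 in this assay is 9000 nM, with a range from 3000 nM to 30000 nM.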

Compound 3, concentration for total growth inhibition: 25700 nM
The estimate for compound 3 lay 2.9-fold (0.46 log units) below the measured number; the range from low to high includes it.
By their numbers in this assay, from the lowest: compounds 1, 2 and 3 (each within the scatter of the next, the first and the last beyond it).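

In this assay, within the data shown here, chloro in place of hydrogen on the aromatic carbon between two ring nitrogen atoms gives a 2.3-fold higher number from compound 1 to compound 3 (0.36 log units; beyond the scatter), the first change at this position whose size can be read. The result shows that this position is not indifferent to substitution: a single added chlorine moves the number beyond the scatter, though only modestly, and towards weaker inhibition of growth. The data shown offer no measurement that would explain this shift.

Whether the higher number is specific to chloro or would also follow from another group at this position remains open, as the compounds shown include no fluoro, methyl or methoxy group there. Also open, from the compounds shown here alone, is whether the step would keep its size on another compound, since the pair of compound 1 and compound 3 is the only one that shows it.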